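The compounds below may be only part of what the source reports. "The series", "measured", "known", "first", "only" and "open" are said of these compounds alone.

Measured in an assay on isolated protein for inhibition of DNA topoisomerase 1 (Homo sapiens), with a stated time of 30 min, tested at 20 uM; a higher number here means a stronger effect of the compound at the concentration tested, a lower number a weaker effect:
compound 1 `Oc1cccc(-c2cc(-c3cccs3)cc(-c3ccccc3O)n2)c1` gives 1.5%
compound 2 `Oc1ccc(-c2cc(-c3cccs3)cc(-c3ccccc3O)n2)cc1` gives 2%
compound 3 `Oc1ccc(-c2cc(-c3ccsc3)cc(-c3cccc(O)c3)n2)cc1` gives "not determined" (no result reported) in this assay, that is, no result reported

Compound 1 and compound 2 differ by 4-hydroxyphenyl in place of 3-hydroxyphenyl on an aromatic carbon, a change that gave a number 0.5 percentage points higher from compound 1 to compound 2 (within the scatter). Compound 4 `Oc1ccc(-c2cc(-c3ccsc3)cc(-c3ccc(O)cc3)n2)cc1` repeats this on compound 3: 4-hydroxyphenyl in place of 3-hydroxyphenyl on an aromatic carbon. The place is not the same word for word: on compound 1 it is meta to a 2-hydroxyphenyl group and meta to a thiophen-2-yl group, on compound 3 meta to a 4-hydroxyphenyl group and meta to a thiophen-3-yl group, so the change is of the same kind rather than the same. How the core of compound 3 differs from the core of compound 1 is not broken down here. Among the measured compounds shown here, compound 3 has no number in this assay, so no step from compound 3 to compound 4 can be sized; the expectation rests only on compound 1 with 1.5% and compound 2 with 2%, and on the same kind of change there staying within the scatter. Compound 4 is expected to give about 3% in this assay, between 0% and 12%.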

Compound 4, a percentage reported as inhibition, at one concentration (the size of the read-out at that concentration, not a potency): 7.5%
The estimate for compound 4 lay 4.5 percentage points below the measured number; the range from low to high includes it.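

Among the compounds shown here, with no result reported for compound 3 in this assay, no step from it to compound 4 can be read. As far as these compounds go, the effect of 4-hydroxyphenyl in place of 3-hydroxyphenyl on this core stays open. No evidence shown bears on a cause.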